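This account rests on a few compounds, and the source may have more. Where it says the series, first, only, none or still open, it means among the compounds named here.

In a functional assay on the whole organism (blood, strain albino) with Mus musculus as the target, with stated times of 6 days and 4 h, at a dose of 0.4 mmol/kg by the oral route (on this read-out higher numbers stand for more inhibition at the one dose given (going by the name of the read-out) and lower numbers for less inhibition), compound 2 `CCNC(=S)NS(=O)(=O)c1ccc(-n2nc(C(=O)O)cc2C)cc1` gives -2%. Compound 3 `CCCNC(=O)NS(=O)(=O)c1ccc(-n2nc(C(=O)O)cc2C)cc1` gives 1% in this assay; the step of a number 3 percentage points higher from compound 2 to compound 3 (within the scatter) follows the change (a group of 6 heavy atoms (4 carbon, 1 nitrogen, 1 oxygen; no ring) in place of a group of 5 heavy atoms (3 carbon, 1 nitrogen, 1 sulfur; no ring), on a sulfonamide nitrogen). Compound 1 `CCCNC(=S)NS(=O)(=O)c1ccc(-n2nc(C(=O)O)cc2C)cc1` is reported in this assay only as a limit, < 1%, which is the limit of < 1% in this assay, at which 1 of the 3 values shown sits. The change from compound 2 to compound 1 is methyl in place of hydrogen on a saturated chain carbon, two bonds along the chain from an amide-type nitrogen, and the step that the limit leaves unreadable from compound 2 to compound 1 has no readable size. Compound 4 `CCCCNC(=O)NS(=O)(=O)c1ccc(-n2nc(C(=O)O)cc2C)cc1` has not yet been measured; it differs from compound 3 by methyl in place of hydrogen on a saturated chain carbon, three bonds along the chain from an amide-type nitrogen, the same kind of change as that from compound 2 to compound 1, the place now being three bonds rather than two bonds along the chain from an amide-type nitrogen. Because the step that the limit leaves unreadable from compound 2 to compound 1 gives no readable size, and because the step of a number 3 percentage points higher from compound 2 to compound 3 (within the scatter) lies within the scatter, compound 4 is expected to give 1% in this assay, an estimated step of no change at the digits printed from compound 3 to compound 4 (within the scatter).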

Compound 4, a percentage reported as inhibition, in the whole organism at one dose (the size of the read-out at that dose, not a potency): 2%
Compound 4: the middle estimate sits 1 percentage points below what was measured; the range from low to high includes it.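

In this assay, methyl in place of hydrogen on a saturated chain carbon, three bonds along the chain from an amide-type nitrogen, gives a number 1 percentage points higher from compound 3 to compound 4 (within the scatter), while the two wider comparisons read a number 4 percentage points higher from compound 2 to compound 4 (within the scatter) and a number at least 1 percentage points higher from compound 1 to compound 4 (that floor lies within the scatter). The same kind of change on the core of compound 2, two bonds along the chain, cannot be read, since compound 1 stands only as a limit: the limit of < 1% in this assay, at which 1 of the 4 values shown sits. The change is thus seen with a readable size on one core only, and whether it carries over to the other is not shown.

The compounds shown leave open what a chain longer than butyl, a cyclohexyl group or an amine on the chain would give. They also leave open what an ester in place of the carboxylic acid would give.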